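Replacing the sulfone aryl group in compound 1

This account rests on a few compounds, and the source may have more. Where it says the series, first, only, none or still open, it means among the compounds named here.

Compound 1 `CC(C)OC(=O)N1CCC(Oc2ncnc3c2CCN3c2ccc(S(C)(=O)=O)cc2F)CC1` is a carbamate bearing an isopropoxy group on its carbonyl carbon. In a functional assay on CHO-K1 cells with Glucose-dependent insulinotropic receptor (Homo sapiens) as the target, read by a luciferase reporter, with a stated time of 5 h (a lower number here means a smaller maximal response, a higher number a larger maximal response), compound 1 gives 91%, the lowest of the three measured values. Compound 2 `COC(=O)N1CCC(Oc2ncnc3c2CCN3c2ccc(S(C)(=O)=O)cc2F)CC1` gives 119% and compound 3 `CSC(=O)N1CCC(Oc2ncnc3c2CCN3c2ccc(S(C)(=O)=O)cc2F)CC1` gives 135%. The measured steps all concern the carbamate end: a number 28 percentage points higher from compound 1 to compound 2 (beyond the scatter), a number 44 percentage points higher from compound 1 to compound 3 (beyond the scatter) and a number 16 percentage points higher from compound 2 to compound 3 (beyond the scatter).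

For the measured compounds named here, compound 4 `CSc1ccc(N2CCc3c(OC4CCN(C(=O)OC(C)C)CC4)ncnc32)cc1F` differs from compound 1 at the other end of the molecule. a group of 9 heavy atoms (7 carbon, 1 fluorine, 1 sulfur; one six-membered aromatic ring of carbon only) in place of a group of 11 heavy atoms (7 carbon, 2 oxygen, 1 fluorine, 1 sulfur; one six-membered aromatic ring of carbon only), on a nitrogen on an aromatic ring in a ring None of the measured steps touches this group, so they give no guide to the direction of the change, and the only anchor is compound 1 itself. Compound 4 is therefore expected to sit near compound 1, with a step of a number 4 percentage points higher from compound 1 to compound 4 (within the scatter) that may well lie within the scatter. The estimate for compound 4 is 95%, in the range from 60% to 130%.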

Compound 4, largest response reached (reported as percent of maximum), in percent of the reference or control that the assay uses: 121%
The estimate for compound 4 lay 26 percentage points below the measured number, and the stated range covers the measured number.
By their numbers in this assay, from the lowest: compound 1; then compounds 2 and 4 (each within the scatter of the next); then compound 3.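

The group on the nitrogen of the five-membered non-aromatic ring proves able to move the maximal response: with the isopropoxy carbamate held constant, the change gives a number 30 percentage points higher from compound 1 to compound 4 (beyond the scatter) in this assay. So far the measured steps had shown this only for the carbamate end, and this one shows that the far end of the molecule also matters, with the 2-fluoro-4-(methylsulfonyl)phenyl group and its 2 hydrogen-bond acceptors giving way to a group with 1. Nothing available explains why the response shifts at this position.

Whether this step adds to the steps at the carbamate end remains open, as the compounds shown do not pair the new group with a methoxy or methylsulfanyl carbonyl. Also open, as far as these compounds go, is how an aryl group carrying a nitrile or a carboxylic acid would compare on this nitrogen.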